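Changing the Para Group from Chloro to Nitro

This account rests on a few compounds, and the source may have more. Where it says the series, first, only, none or still open, it means among the compounds named here.

Compound 2 `CCOC(=O)C1=C(C)NC(C)=C(C(=O)OCC)C1c1c(-c2ccc(Cl)cc2)nc2sc(Cl)cn12` stands at the highest of the two numbers measured in an ADME assay on Left cardiac atrium (Cavia porcellus); on this read-out higher numbers stand for an effect only at larger amounts of compound and lower numbers for an effect already at smaller amounts: compound 2 gives 3500 nM. Its nearest neighbour, compound 1 `CCOC(=O)C1=C(C)NC(C)=C(C(=O)OCC)C1c1c(-c2ccc(F)cc2)nc2sc(Cl)cn12`, gives 49 nM in this assay. Among the compounds with values here, the one measured step, a 71-fold higher number from compound 1 to compound 2 (1.85 log units; beyond the scatter), is a large move at the very position that changes next.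

Compound 3 `CCOC(=O)C1=C(C)NC(C)=C(C(=O)OCC)C1c1c(-c2ccc([N+](=O)[O-])cc2)nc2sc(Cl)cn12` differs from compound 2 by nitro in place of chloro on an aromatic carbon. Within the data shown here, no measured pair shows a nitro group entering, so the only guide is the step from compound 1 to compound 2, which touched the same aromatic carbon and was far beyond the scatter. This makes a large change plausible for compound 3 as well, yet its direction cannot be read from a single step, and a number close to that of compound 2 is as defensible as a move either way. Compound 3 is therefore expected to give about 2500 nM in this assay, within a wide range from 250 nM to 25000 nM. The expected step of a 1.4-fold lower number from compound 2 to compound 3 (0.15 log units; within the scatter) is small in its middle value but carries much uncertainty.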

Compound 3, half-maximal effective concentration: 1370 nM
Beside the measured number, compound 3's estimate is 1.8-fold (0.26 log units) above it; the measured number falls inside the stated range.
By their numbers in this assay, from the lowest: compound 1; then compound 3; then compound 2.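

With a third group now measured on this aromatic carbon, para to a large group, this assay shows that exchanging one group for another here need not produce a large jump: the change to nitro gives a 2.6-fold lower number from compound 2 to compound 3 (0.41 log units; beyond the scatter), a modest move that is still beyond the usual scatter. The comparison with the fluoro compound tells a different story, with a 28-fold higher number from compound 1 to compound 3 (1.45 log units; beyond the scatter), so the high number seen with chloro is not unique to chloro, and compound 1 remains clearly the lowest of the three. Nitro, with 3 heavy atoms, also gives a lower number than chloro, with 1 heavy atom, so among these two groups more heavy atoms do not go with a higher number.

No experimental information accompanies these numbers to say why fluoro stands so far from chloro and nitro. Going by these compounds, it remains open whether a methoxy group, an amine or a carboxylic acid on this same carbon would give a number near that of compound 1 or in the higher range of compound 2 and compound 3.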